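The source may hold more compounds than are shown below. What is called first, only, known or untested is meant among the compounds shown, and "the series" means these compounds.

Measured in a toxicity assay on MT4 cells (Homo sapiens) for cytotoxicity, read by MTT assay, with a stated time of 5 days; a lower number here means that less compound is tolerated, a higher number that more compound is tolerated:
- compound 1 `Cc1cnc(Nc2ccc(C#N)cc2)nc1Nc1c(F)cc(-c2cccnc2)cc1F`: 1100 nM
- compound 2 `Cc1cnc(Nc2ccc(C#N)cc2)nc1Nc1c(F)cc(-c2cncnc2)cc1F`: 900 nM
- compound 3 `Cc1cc(-c2cc3ccccc3s2)cc(C)c1Nc1ccnc(Nc2ccc(C#N)cc2)n1`: 138000 nM

Compound 3 has the highest number of the three, so it is the best tolerated, and its distance from the other two is beyond the usual scatter. The next compound, compound 4 `Cc1cc(-c2ccnc(C(F)(F)F)c2)cc(C)c1Nc1ccnc(Nc2ccc(C#N)cc2)n1`, carries 2-(trifluoromethyl)pyridin-4-yl in place of 1-benzothiophen-2-yl on an aromatic carbon.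

Within the data shown here, only one measured step bears on this change, and only loosely. In a 1.2-fold lower number from compound 1 to compound 2 (0.09 log units; within the scatter), one ring group replaces another with no change beyond the scatter. That step does not involve 1-benzothiophen-2-yl, so the data do not show what removing this group does on its own.

Compound 4 keeps the two methyl groups of compound 3 138000 nM, but its new group is closer by name to the pyridin-3-yl of compound 1 1100 nM. A value between these two is therefore expected. The expected step is a 6.9-fold lower number from compound 3 to compound 4 (0.84 log units; beyond the scatter), and this estimate is very uncertain. The estimate for compound 4 is 20000 nM, with an expected range from 4000 nM to 100000 nM.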

Compound 4, half-maximal cytotoxic concentration: 6100 nM
Beside the measured number, compound 4's estimate is 3.3-fold (0.52 log units) above it, within the range that was stated.
By their numbers in this assay, from the lowest: compounds 2 and 1 (each within the scatter of the next); then compound 4; then compound 3.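

In this assay, replacing 1-benzothiophen-2-yl with 2-(trifluoromethyl)pyridin-4-yl gives a 23-fold lower number from compound 3 to compound 4 (1.35 log units; beyond the scatter), so the group on this aromatic carbon, meta to two methyl groups, clearly affects the cytotoxic concentration. The only earlier step, a 1.2-fold lower number from compound 1 to compound 2 (0.09 log units; within the scatter), also exchanged one ring group for another but showed no change beyond the scatter, so this is the first exchange shown to move the number by more. No measurement here explains the size of this step.

Because this change alters the ring and adds trifluoromethyl at once, the compounds shown cannot separate the two, and a plain pyridin-4-yl group would be needed to do so. As far as these compounds go, it also remains open how a non-aromatic group at this same carbon, such as an amine or a carboxylic acid, would behave.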